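The source may hold more compounds than are shown below. What is called first, only, known or untested is meant among the compounds shown, and "the series" means these compounds.

In a functional assay on HEK293 cells for agonist activity at Bile acid receptor (Homo sapiens) (a higher number here means a larger maximal response, a lower number a smaller maximal response), compound 1 `CC(C)c1onc(-c2c(Cl)cccc2Cl)c1COc1ccc(NC(=O)c2ccc(C(=O)O)cc2)c(C(F)(F)F)n1` gives 21%, compound 2 `CC(C)c1onc(-c2c(Cl)cccc2Cl)c1COc1ccc(NCc2ccc(C(=O)O)cc2)c(C(F)(F)F)n1` gives 48%, and compound 3 `CC(C)c1onc(-c2c(Cl)cccc2Cl)c1COc1ccc(N(C)Cc2cccc(C(=O)O)c2)c(C(F)(F)F)n1` gives 89%. Compound 3 stands highest of the three: the nearest is compound 2, with a number 41 percentage points higher from compound 2 to compound 3 (beyond the scatter), and compound 1 lies furthest, with a number 68 percentage points higher from compound 1 to compound 3 (beyond the scatter). Compound 4 `CC(C)c1onc(-c2c(Cl)cccc2Cl)c1COc1ccc(N(C)Cc2ccc(OCCO)cc2)c(C(F)(F)F)n1` differs from compound 3 in one place: 4-(2-hydroxyethoxy)phenyl in place of 3-carboxyphenyl on a saturated chain carbon bound to a nitrogen on an aromatic ring. For the measured compounds named here, every measured step kept a carboxylic acid, so none tests its removal; the steps of a number 27 percentage points higher from compound 1 to compound 2 (beyond the scatter) and a number 41 percentage points higher from compound 2 to compound 3 (beyond the scatter) show only that changes in this part of the molecule moved the maximal response strongly. The direction of this step is therefore open, and a step of either sign beyond the scatter is possible. Compound 4 is estimated at 55%, within 20% to 95%, an expected step of a number 34 percentage points lower from compound 3 to compound 4 (beyond the scatter).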

Compound 4, largest response reached (reported as efficacy), in percent of the reference or control that the assay uses: 43%
Compound 4: the middle estimate sits 12 percentage points above what was measured, and the stated range covers the measured number.
By their numbers in this assay, from the lowest: compound 1; then compounds 4 and 2 (each within the scatter of the next); then compound 3.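

Putting 4-(2-hydroxyethoxy)phenyl in place of 3-carboxyphenyl gives a number 46 percentage points lower from compound 3 to compound 4 (beyond the scatter). This is the only step shown that removes the carboxylic acid, and it shows that a compound without that acid still gives a sizeable maximal response, though a much smaller one. The change alters both the group and where it sits on the ring, and nothing available explains the loss. Still open, going by these compounds, is whether 3-(2-hydroxyethoxy)phenyl or 3-aminophenyl would keep the response of compound 3, which would separate the effect of the group from that of its place.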